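The source may hold more compounds than are shown below. What is called first, only, known or untested is meant among the compounds shown, and "the series" means these compounds.

Compound 3, `Cc1c(OC[C@@H](C)COc2cc(C(=O)O)ccc2F)ccc(C(=O)CC(C)(C)C)c1O`, stands at the top of the three numbers measured in an assay for positive allosteric modulation of metabotropic glutamate receptor 3 (Rattus norvegicus) (a higher number here means that more compound is needed for the effect, a lower number that less compound is needed), where compound 3 gives 3950 nM. Compound 1, `Cc1c(OCCCCOc2ccc(C(=O)O)cc2F)ccc(C(=O)CC(C)(C)C)c1O`, gives 1230 nM in this assay, and compound 2, `COc1ccc(C(=O)O)cc1OC[C@H](C)COc1ccc(C(=O)CC(C)(C)C)c(O)c1C`, gives 384 nM. The only single-point step among these three runs a 10-fold higher number from compound 2 to compound 3 (1.01 log units; beyond the scatter), a fluoro in place of a methoxy on an aromatic carbon.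

Compound 4, `Cc1cc(C(=O)O)ccc1OC[C@H](C)COc1ccc(C(=O)CC(C)(C)C)c(O)c1C`, differs from compound 3 in the ring at the far end of the linker: 4-carboxy-2-methylphenyl in place of 5-carboxy-2-fluorophenyl on an oxygen on a saturated carbon. Here the fluorine leaves again, now for a methyl rather than a methoxy, and the carboxy sits at a different point of that ring. Among the compounds with values here, no measured step matches this change exactly. The step from compound 2 to compound 3 is the nearest guide, and since the fluorine departs, a step back toward lower numbers of a smaller size is expected, a 4.9-fold lower number from compound 3 to compound 4 (0.69 log units; beyond the scatter). Compound 4 is therefore estimated at 800 nM, with a range from 250 nM to 2500 nM.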

Compound 4, half-maximal effective concentration: 1520 nM
Compound 4: the middle estimate sits 1.9-fold (0.28 log units) below what was measured; low and high end bracket the measured number.
By their numbers in this assay, from the lowest: compound 2; then compounds 1 and 4 (each within the scatter of the next); then compound 3.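

In this assay, putting 4-carboxy-2-methylphenyl in place of 5-carboxy-2-fluorophenyl on the oxygen gives a 2.6-fold lower number from compound 3 to compound 4 (0.41 log units; beyond the scatter), so the number also moves when the fluorine gives way to a methyl, not only to a methoxy. Compound 3 now stands above both compounds that differ from it only in this ring, yet compound 2 gives 384 nM and compound 4 gives 1520 nM, so the two replacement rings are not equivalent. Nothing available explains the size or direction of this step.

As far as these compounds go, this swap changes the ring substituent and the place of the carboxy group together, so the share of each in the step stays open. Also open, from the compounds shown here alone, is what a ring with a chlorine in place of the methyl, or a tetrazole in place of the carboxylic acid, would give.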